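The source may report more compounds than this note shows. Statements on the series, on what has been measured and on what is new or still open speak of the compounds shown alone.

Measured in a functional assay on HCT-116 cells (Homo sapiens) for cytotoxicity, read by MTT assay; on this read-out lower numbers stand for stronger inhibition and higher numbers for weaker inhibition:
- Compound 1 `Cc1cc(O)c(C(=O)/C=C/c2ccc(F)cc2)c(=O)o1`: > 100000 nM (a limit)
- Compound 2 `Cc1cc(O)c(C(=O)/C=C/c2ccc(Cl)cc2)c(=O)o1`: 87400 nM
- Compound 3 `CCOc1ccc(/C=C/C(=O)c2c(O)cc(C)oc2=O)cc1`: > 100000 nM (a limit)

Compound 3 is known in this assay only as a limit, > 100000 nM. This is the limit of > 100000 nM in this assay, at which 2 of the 3 values shown sit. Compound 4 `Cc1cc(O)c(C(=O)/C=C/c2ccc(N(C)C)cc2)c(=O)o1` carries dimethylamino in place of ethoxy on an aromatic carbon, para to a large group: dimethylamino in place of ethoxy on an aromatic carbon.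

The measured steps give little to go on. They comprise an at least 1.1-fold lower number from compound 1 to compound 2 (0.05 log units; that floor lies within the scatter), an at least 1.1-fold higher number from compound 2 to compound 3 (0.05 log units; that floor lies within the scatter) and a step that the two limits leave unreadable from compound 1 to compound 3. None of them shows a change beyond the scatter, so no step beyond the scatter is expected in this assay, in either direction. The expected step is an at least 1.1-fold lower number from compound 3 to compound 4 (0.04 log units; that floor lies within the scatter). Compound 4 is estimated at 90000 nM, with an expected range from 45000 nM to 180000 nM.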

Compound 4, half-maximal inhibitory concentration: > 100000 nM
Compound 4 was reported as a limit; the forecaster's own chance of this, stated with the estimate: 65%; at least 1.1-fold (0.04 log units) between middle value and limit.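

In this assay compound 4 gives > 100000 nM, which is a limit. Dimethylamino at this place, para to a large group, therefore adds a third group reported as a limit, and the only readable comparison is an at least 1.1-fold higher number from compound 2 to compound 4 (0.05 log units; that floor lies within the scatter); the steps that join compound 4 to compound 1 and compound 3 cannot be read. No readable step shows a change beyond the scatter, and the series stays mostly at one ceiling: the limit of > 100000 nM in this assay, at which 3 of the 4 values shown sit.

Going by these compounds, whether a carboxylic acid or a primary amine at this place would give a measurable number stays open. So does how far compound 1, compound 3 and compound 4 truly lie from one another.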